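A few compounds are considered here, and "the series" means these few. Any claim that something is new, unique, unknown or untested is made for them only; others in the source may bear on it.

Measured compounds:
- compound 1 `C=C1CC[C@@H]2[C@](C)(CCC[C@]2(C)C(=O)OC)[C@H]1CCc1ccc2c(OC(C)=O)ccc(OC(C)=O)c2c1`: 120 nM
- compound 2 `C=C1CC[C@@H]2[C@](C)(CCC[C@]2(C)C(=O)OC)[C@H]1CCc1ccc2c(OCc3ccccc3)ccc(OCc3ccccc3)c2c1`: > 5000 nM
- compound 3 `C=C1[C@H](O)C[C@@H]2[C@](C)(CCC[C@]2(C)C(=O)OC)[C@H]1CCc1ccc2c(OC(C)=O)ccc(OC(C)=O)c2c1`: 1600 nM

The three measured compounds were tested in a functional assay on A549 cells (Homo sapiens) for cytotoxicity, read by sulforhodamine B assay, with a stated time of 72 h; a lower number here means a stronger inhibitor of growth, a higher number a weaker inhibitor of growth. Compound 1 gives 120 nM. Compound 3 gives 1600 nM, and the change that separates them, (hydroxy in place of hydrogen on a saturated ring carbon), produced a 13-fold higher number from compound 1 to compound 3 (1.12 log units; beyond the scatter). For compound 2 the reading of > 5000 nM is a limit of the assay and not a number. The difference between the core of compound 1 and the core of compound 2 is not broken down here.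

Compound 4, `C=C1CC[C@@H]2[C@](C)(CCC[C@]2(C)C(=O)OC)[C@]1(O)CCc1ccc2c(OCc3ccccc3)ccc(OCc3ccccc3)c2c1`, has not yet been measured. It differs from compound 2 by hydroxy in place of hydrogen on a saturated ring carbon. For the measured compounds named here, this is the same kind of change as the one from compound 1 to compound 3, but not the same: in compound 4 the hydroxy sits next to the ring atom that bears a fused ring and next to the ring atom that bears a methyl group, whereas in compound 3 it sits two ring bonds from the ring atom that bears a fused ring and three ring bonds from the ring atom that bears a methyl group.

The step from compound 2 to compound 4 in this assay is expected to be a step that the limit leaves unreadable from compound 2 to compound 4, which cannot be resolved because compound 2 already sits at the limit of > 5000 nM in this assay, at which 1 of the 3 values shown sits. Compound 4 is therefore expected at about 30000 nM, with a plausible range from 5000 nM to 200000 nM, and most likely the assay will again report only a limit.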

Compound 4, concentration for 50% growth inhibition: 12400 nM
For compound 4 the middle estimate is 2.4-fold (0.38 log units) above the measured one, within the range that was stated.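

In this assay compound 4 gives 12400 nM as a measured number. For the compounds shown here, compound 2 carries only a limit, so no step from compound 2 to compound 4 can be read: the limit of > 5000 nM in this assay, at which 1 of the 4 values shown sits. The compounds shown leave open what hydroxy in place of hydrogen on this saturated ring carbon does in the core of compound 2, and how that compares with a 13-fold higher number from compound 1 to compound 3 (1.12 log units; beyond the scatter) in size.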